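Switching the amide nitrogen substituent to a dimethyl-oxazolyl group

The source may hold more compounds than are shown below. What is called first, only, known or untested is meant among the compounds shown, and "the series" means these compounds.

Measured compounds:
compound 1 `COc1cc2nc(C)cc(OCC(=O)Nc3cc(C)cc(C)c3)c2cc1OC`: 4.84
compound 2 `COc1ccc2nc(C)cc(OCC(=O)Nc3ccc(Br)c(C)c3)c2c1`: 5.95

Of the compounds shown here, two have been measured in a physicochemical assay for lipophilicity, read by HPLC, in phosphate buffer, measured as chromatographic lipophilicity, at pH 7.4; on this read-out lower numbers stand for lower lipophilicity and higher numbers for higher lipophilicity. Compound 1 gives 4.84 in this assay, and compound 2 gives 5.95. Compound 2 has the highest number of the two, and its nearest neighbour, compound 1, sits a number lower that lies beyond the scatter. Within the data shown here, no single-change pair has been measured, so the two values can only be set side by side.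

Compound 3 `COc1ccc2nc(C)cc(OCC(=O)Nc3noc(C)c3C)c2c1` is the unmeasured compound. It differs from compound 2 in one place (4,5-dimethyl-1,2-oxazol-3-yl in place of 4-bromo-3-methylphenyl on an amide-type nitrogen). The group that leaves carries a bromine atom on a six-membered aromatic ring of carbon only, while the group that enters is a five-membered aromatic ring with two hetero atoms and two hydrogen-bond acceptors. This assay is expected to show a step downward, well beyond the scatter, from compound 2 to compound 3 of a number 1.65 log units lower from compound 2 to compound 3 (beyond the scatter). Compound 3 is therefore estimated at 4.3 in this assay, with an expected range from 3.7 to 4.9.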

Compound 3, distribution coefficient: 3.3
For compound 3 the middle estimate is 1.00 log units above the measured one; measured number outside the range, below it.
By their numbers in this assay, from the lowest: compound 3; then compound 1; then compound 2.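

Among these compounds, exchanging 4-bromo-3-methylphenyl for 4,5-dimethyl-1,2-oxazol-3-yl on the amide-type nitrogen gives, in this assay, a number 2.65 log units lower from compound 2 to compound 3 (beyond the scatter), the first step here that can be tied to one place. The earlier compounds shown here formed no such pair, so they could not show that a change at this position alone moves the read-out by so large an amount. Nothing available here speaks to the cause of the step.

The compounds shown leave open how much of the step goes with the loss of the bromine and how much with the exchange of the ring, a question that a 3-methylphenyl group on the same nitrogen would help to answer. Also open, going by these compounds, is whether the same exchange would give a step of similar size on the core of compound 1.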